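From carboxy to ethoxycarbonyl at the assay limit

The source may report more compounds than this note shows. Statements on the series, on what has been measured and on what is new or still open speak of the compounds shown alone.

Measured in an ADME assay on HaCaT cells (Homo sapiens) for antiproliferative activity, with a stated time of 48 h (a higher number here means a weaker inhibitor, a lower number a stronger inhibitor), so far:
Compound 1 `CCN(CC)c1ccc(-c2ccc(C#N)cc2)nn1` gives > 25000 nM as a limit
Compound 2 `CCN(CC)c1ccc(-c2ccc(C(=O)O)cc2)nn1` gives > 25000 nM as a limit

Compound 2 stands only at > 25000 nM in this assay and this is a limit, not a number. Compound 3 `CCOC(=O)c1ccc(-c2ccc(N(CC)CC)nn2)cc1` is reached from it by ethyl in place of hydrogen on an oxygen next to a carbonyl group (carboxy to ethoxycarbonyl). Going by the values given here, the one measured step, a step that the two limits leave unreadable from compound 1 to compound 2 here, bears on this change only loosely and gives no size to carry over. Both measured compounds share a single limit (the limit of > 25000 nM in this assay, at which 2 of the 2 values shown sit) and no direction can be read from them. No step beyond the scatter is therefore expected, and compound 3 will most likely be reported as a limit again. The expected step is a step that the limit leaves unreadable from compound 2 to compound 3 and no larger one is foreseen. For compound 3 the estimated value is 30000 nM with an expected range from 12000 nM to 80000 nM in this assay.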

Compound 3, half-maximal inhibitory concentration: 500 nM
The estimate for compound 3 lay 60-fold (1.78 log units) above the measured number, and the stated range ends above it.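

In this assay, going by these compounds alone, ethyl in place of hydrogen on an oxygen next to a carbonyl group gives an at least 50-fold lower number from compound 2 to compound 3 (1.69 log units; beyond the scatter), the first step in this set whose lower bound can be read. The change from cyano to ethoxycarbonyl gives an at least 50-fold lower number from compound 1 to compound 3 (1.69 log units; beyond the scatter), so the group at this aromatic carbon can bring the number down from the limit, which neither carboxy nor cyano had shown. The step between compound 1 and compound 2 cannot be read, and compound 3 alone has a number, as the other two values remain limits: the limit of > 25000 nM in this assay, at which 2 of the 3 values shown sit.

From the compounds shown here alone, the full size of both readable steps stays open, since each is measured from a limit. Also open, going by these compounds, is whether methoxycarbonyl, a longer chain on the oxygen, or an amide in place of the ethoxycarbonyl would keep the number this low.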